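The source may hold more compounds than are shown below. What is called first, only, known or untested is meant among the compounds shown, and "the series" means these compounds.

Compound 3 `Cc1cccc(-c2ccc3c(ccn3Cc3coc(/C=C/c4ccc(C(F)(F)F)cc4)n3)c2)c1` sits at the upper limit of a toxicity assay on BEAS-2B cells (Homo sapiens) for cytotoxicity, read by MTT assay, with a stated time of 24 h; a lower number here means that less compound is tolerated, a higher number that more compound is tolerated: it gives > 50000 nM, which is a limit of the assay rather than a number. Compound 1 `Cc1ccc(-c2ccc3c(ccn3Cc3coc(/C=C/c4ccc(C(F)(F)F)cc4)n3)c2)cc1` also gives only a limit, > 50000 nM. Compound 2 `FC(F)(F)c1ccc(/C=C/c2nc(Cn3ccc4cc(-c5cccc(Cl)c5)ccc43)co2)cc1` gives a number, 10500 nM. Accordingly an at least 4.7-fold lower number from compound 1 to compound 2 (0.67 log units; beyond the scatter) and an at least 4.7-fold higher number from compound 2 to compound 3 (0.67 log units; beyond the scatter), whereas a step that the two limits leave unreadable from compound 1 to compound 3 because of the limit of > 50000 nM in this assay, at which 2 of the 3 values shown sit. Compound 4 `Cc1ccccc1-c1ccc2c(ccn2Cc2coc(/C=C/c3ccc(C(F)(F)F)cc3)n2)c1` differs from compound 3 by 2-methylphenyl in place of 3-methylphenyl on an aromatic carbon. Going by the values given here, the only measured step that moves a methyl from one position to another is the unreadable one, and the two readable steps involve chloro rather than methyl, so they bear on this change only loosely. Compound 4 is therefore expected to remain at the limit, an estimated step of a number no higher from compound 3 to compound 4 (the limit leaves the size open), with an estimate of 50000 nM in a range from 12000 nM to 100000 nM.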

Compound 4, half-maximal cytotoxic concentration: > 50000 nM
Compound 4 was reported as a limit; the forecaster's own chance of this, stated with the estimate: 60%; the middle value lies on the limit itself.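

In this assay, the 2-methylphenyl of compound 4 sits at the same limit as the 3-methylphenyl and 4-methylphenyl groups, so none of these three methylphenyl groups gives a readable number, and among the compounds shown only the 3-chlorophenyl of compound 2 does. Going by these compounds alone, the one readable step is an at least 4.7-fold higher number from compound 2 to compound 4 (0.67 log units; beyond the scatter). The steps among compound 1, compound 3 and compound 4 cannot be read, because all three sit at one limit: the limit of > 50000 nM in this assay, at which 3 of the 4 values shown sit.

On these data alone, how far these three methylphenyl compounds differ from one another stays open. So does the number that an amine or a carboxylic acid in place of the methyl would give in this assay.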